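Trifluoromethoxy for Trifluoromethyl: Expectation for Compound 4

This account rests on a few compounds, and the source may have more. Where it says the series, first, only, none or still open, it means among the compounds named here.

Three measured compounds share one core and differ only in the group carried on the sulfur. In a functional assay on CWR22R cells (Homo sapiens) for antiproliferative activity, read by propidium iodide staining, with a stated time of 96 h (on this read-out lower numbers stand for stronger inhibition and higher numbers for weaker inhibition), compound 1 `CC(O)(CSc1cccc(C(F)(F)F)c1)C(=O)Nc1ccc(S(F)(F)(F)(F)F)cc1` gives 23400 nM. Compound 2 `CC(O)(CSc1ccccc1C(F)(F)F)C(=O)Nc1ccc(S(F)(F)(F)(F)F)cc1` gives 13200 nM in this assay, and compound 3 `CC(O)(CSc1cccc(OC(F)(F)F)c1)C(=O)Nc1ccc(S(F)(F)(F)(F)F)cc1` gives 14000 nM. The cores of compound 1 and compound 2 differ by 2-(trifluoromethyl)phenyl in place of 3-(trifluoromethyl)phenyl on a sulfur, and that change brought a 1.8-fold lower number from compound 1 to compound 2 (0.25 log units; within the scatter). Compound 3 arises from compound 1 by trifluoromethoxy in place of trifluoromethyl on an aromatic carbon, a change that brought a 1.7-fold lower number from compound 1 to compound 3 (0.22 log units; within the scatter). Compound 4 `CC(O)(CSc1ccccc1OC(F)(F)F)C(=O)Nc1ccc(S(F)(F)(F)(F)F)cc1` has not been measured; it arises from compound 2 by trifluoromethoxy in place of trifluoromethyl on an aromatic carbon, the same kind of change, though here the place is ortho to a large group rather than meta to a large group. Because the earlier instance brought a 1.7-fold lower number from compound 1 to compound 3 (0.22 log units; within the scatter), the step expected for compound 4 is a 1.5-fold lower number from compound 2 to compound 4 (0.17 log units; within the scatter), kept modest since that step lay within the scatter. The estimate for compound 4 in this assay is 9000 nM, between 4000 nM and 20000 nM.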

Compound 4, half-maximal inhibitory concentration: 15000 nM
For compound 4 the middle estimate is 1.7-fold (0.22 log units) below the measured one; low and high end bracket the measured number.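

In this assay, trifluoromethoxy in place of trifluoromethyl on the core of compound 2 brought a 1.1-fold higher number from compound 2 to compound 4 (0.06 log units; within the scatter). Set beside the earlier instance, this step does not differ from it by more than repeated measurement would allow: the same change on two cores in this assay, a 1.7-fold lower number (0.22 log units; within the scatter) from compound 1 to compound 3 and a 1.1-fold higher number (0.06 log units; within the scatter) from compound 2 to compound 4, 1.9-fold (0.28 log units) apart, within the scatter of two such steps. The change therefore carries between these two cores without a step that stands out from the scatter, but with both steps inside the scatter, this does not show that the change has any real effect on either core, or that its direction is fixed.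

The compounds shown leave open what a nitrile, an amine or a carboxylic acid in place of trifluoromethoxy would give in this assay. They also leave open whether any such group would produce a step beyond the scatter.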